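A few compounds are considered here, and "the series" means these few. Any claim that something is new, unique, unknown or untested is made for them only; others in the source may bear on it.

Measured compounds:
compound 1 `CC(C)NC(=O)N1CCN(C(=S)SCc2cn(Cc3ccccc3F)nn2)CC1`: 20800 nM
compound 2 `CCN(C)C(=O)N1CCN(C(=S)SCc2cn(Cc3ccccc3F)nn2)CC1`: 15600 nM
compound 3 `CC(C)NC(=O)N1CCN(C(=S)SCc2cn(Cc3ccc(F)cc3)nn2)CC1`: 12200 nM

All three were read in a functional assay on EC9706 cells (Homo sapiens) for cytotoxicity, read by MTT assay, with a stated time of 72 h; a higher number here means a weaker inhibitor, a lower number a stronger inhibitor. Compound 2 differs from compound 1 by ethyl(methyl)amino in place of isopropylamino on a carbonyl carbon; the step is a 1.3-fold lower number from compound 1 to compound 2 (0.12 log units; within the scatter). Compound 3 differs from compound 1 by 4-fluorophenyl in place of 2-fluorophenyl on a saturated chain carbon bound to an aromatic nitrogen; that step is a 1.7-fold lower number from compound 1 to compound 3 (0.23 log units; within the scatter). Compound 3 has the lowest of the three numbers, but its gap to compound 2 and to compound 1 lies within the scatter, so no order among the three can be claimed.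

Compound 4 `CCN(C)C(=O)N1CCN(C(=S)SCc2cn(Cc3ccc(F)cc3)nn2)CC1` is not yet measured. It differs from compound 3 by ethyl(methyl)amino in place of isopropylamino on a carbonyl carbon. This is the same change as from compound 1 to compound 2, made on the core of compound 3 instead of the core of compound 1; the two cores differ as given under (4-fluorophenyl in place of 2-fluorophenyl on a saturated chain carbon bound to an aromatic nitrogen), and the place of the change is the same in both pairs. The step from compound 3 to compound 4 in this assay is expected to be a 1.3-fold lower number from compound 3 to compound 4 (0.11 log units; within the scatter), beside a 1.3-fold lower number from compound 1 to compound 2 (0.12 log units; within the scatter), because the same change made the earlier step of a 1.3-fold lower number from compound 1 to compound 2 (0.12 log units; within the scatter). The estimate for compound 4 in this assay is 9500 nM, expected between 4000 nM and 22000 nM.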

Compound 4, half-maximal inhibitory concentration: 14300 nM
For compound 4 the middle estimate is 1.5-fold (0.18 log units) below the measured one; the measured number falls inside the stated range.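

In this assay, ethyl(methyl)amino in place of isopropylamino on the core of compound 3 gives a 1.2-fold higher number from compound 3 to compound 4 (0.07 log units; within the scatter), and the two readings of this change do not differ beyond the scatter: the same change on two cores in this assay, a 1.3-fold lower number (0.12 log units; within the scatter) from compound 1 to compound 2 and a 1.2-fold higher number (0.07 log units; within the scatter) from compound 3 to compound 4, 1.6-fold (0.19 log units) apart, within the scatter of two such steps
The change from 2-fluorophenyl to 4-fluorophenyl, read on the second core as a 1.1-fold lower number from compound 2 to compound 4 (0.04 log units; within the scatter), likewise agrees with its earlier step: the same change on two cores in this assay, a 1.7-fold lower number (0.23 log units; within the scatter) from compound 1 to compound 3 and a 1.1-fold lower number (0.04 log units; within the scatter) from compound 2 to compound 4, 1.6-fold (0.19 log units) apart, within the scatter of two such steps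
This shows that neither change behaves measurably differently between these two cores, but every step involved lies within the scatter, so the agreement is between small steps: it does not show that either change has a real effect, and it does not show that a step of larger size would carry over.

Still open, on these data alone, is whether any group at these two places moves the number beyond the scatter. A longer chain such as butylamino on the carbonyl carbon, or chlorophenyl in place of fluorophenyl, would put that question to the series.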